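The compounds below may be only part of what the source reports. "The series", "measured", "known", "first", "only" and "open" are said of these compounds alone.

Measured compounds:
compound 1, `Cc1nccn1-c1cnc(NCc2c(F)ccc3c2CCO3)c2cn[nH]c(=O)c12`, 2.1
compound 2, `O=C1CCCN1c1cnc(NCc2c(F)ccc3c2CCO3)c2cn[nH]c(=O)c12`, 1.8
compound 3, `CC(=O)N1CCC(c2cnc(NCc3c(F)ccc4c3CCO4)c3cn[nH]c(=O)c23)CC1`, 2.9

In a physicochemical assay for lipophilicity, using the shake flask method, in phosphate buffer, measured as octanol-water partition, with a stated time of 30 min, at pH 7.4 (on this read-out lower numbers stand for lower lipophilicity and higher numbers for higher lipophilicity), compound 3 stands highest of the three: the step of a number 0.80 log units higher from compound 1 to compound 3 (beyond the scatter) and the step of a number 1.10 log units higher from compound 2 to compound 3 (beyond the scatter) both lie beyond the scatter, while the step of a number 0.30 log units lower from compound 1 to compound 2 (within the scatter) does not.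

Compound 4, `Cc1nn(C)cc1-c1cnc(NCc2c(F)ccc3c2CCO3)c2cn[nH]c(=O)c12`, is not yet measured. The change from compound 3 is 1,3-dimethyl-1H-pyrazol-4-yl in place of 1-acetylpiperidin-4-yl on an aromatic carbon. Among the measured compounds shown here, the steps that bear on it are a number 0.80 log units higher from compound 1 to compound 3 (beyond the scatter) and a number 1.10 log units higher from compound 2 to compound 3 (beyond the scatter), both beyond the scatter, both running upward toward the 1-acetylpiperidin-4-yl group of compound 3. Compound 1 carries a five-membered aromatic ring in the same place and gives 2.1. Compound 4 is therefore expected to fall below compound 3 by a modest step, a number 0.40 log units lower from compound 3 to compound 4 (beyond the scatter), beyond the scatter. The estimate for compound 4 is 2.5, with a range from 2 to 3.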

Compound 4, distribution coefficient: 2.8
For compound 4 the middle estimate is 0.30 log units below the measured one; measured number inside the range.
By their numbers in this assay, from the lowest: compounds 2 and 1 (each within the scatter of the next); then compounds 4 and 3 (each within the scatter of the next).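

In this assay, replacing the 1-acetylpiperidin-4-yl group with 1,3-dimethyl-1H-pyrazol-4-yl leaves the number level (a number 0.10 log units lower from compound 3 to compound 4 (within the scatter)), so a five-membered aromatic ring at this position need not give a number near that of compound 1. The two five-membered aromatic rings differ clearly (a number 0.70 log units higher from compound 1 to compound 4 (beyond the scatter)), and the 2-oxopyrrolidin-1-yl group also lies well apart (a number 1.00 log units higher from compound 2 to compound 4 (beyond the scatter)). Nothing available gives a cause for these steps. On these data alone, whether an amine or a carboxylic acid here would fall outside this span remains open, as does the separate contribution of each pyrazole methyl group.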